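Ethynyl in place of benzofuranyl on the dimethylamino core

The source may hold more compounds than are shown below. What is called first, only, known or untested is meant among the compounds shown, and "the series" means these compounds.

Compound 3 `CN(C)c1ncnc2c1c(-c1cc3ccccc3o1)cn2[C@@H]1O[C@H](CO)[C@@H](O)[C@H]1O` carries a dimethylamino group on the shared core together with a 1-benzofuran-2-yl group. In a functional assay on HepG2 cells (Homo sapiens) for antiproliferative activity, read by XTT assay, with a stated time of 72 h (on this read-out lower numbers stand for stronger inhibition and higher numbers for weaker inhibition), compound 3 gives only a limit, > 20000 nM. Compound 2 `COc1ncnc2c1c(-c1ccccc1)cn2[C@@H]1O[C@H](CO)[C@@H](O)[C@H]1O` likewise gives only a limit in this assay, > 20000 nM. Compound 1 `C#Cc1cn([C@@H]2O[C@H](CO)[C@@H](O)[C@H]2O)c2ncnc(OC)c12` gives a number in this assay, 12700 nM. Compound 3 thus stands at the limit of > 20000 nM in this assay, at which 2 of the 3 values shown sit, without a number of its own.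

Compound 4 `C#Cc1cn([C@@H]2O[C@H](CO)[C@@H](O)[C@H]2O)c2ncnc(N(C)C)c12` differs from compound 3 by ethynyl in place of 1-benzofuran-2-yl on an aromatic carbon. Among the compounds with values here, the one measured step that bears on this change runs in the opposite direction: an at least 1.5-fold higher number from compound 1 to compound 2 (0.19 log units; that floor lies within the scatter), with phenyl in place of ethynyl. Its floor lies within the scatter, and compound 2 is itself a limit, so the true size of that step is not known. Read in reverse, replacing an aryl group by ethynyl on the same aromatic carbon is expected to lower the number, by an amount that a limit cannot fix. A step of an at least 1.6-fold lower number from compound 3 to compound 4 (0.22 log units; that floor lies within the scatter) is therefore expected. Compound 4 is estimated at 12000 nM in this assay, with a range from 5000 nM to 30000 nM. A real chance remains that compound 4 again returns only a limit.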

Compound 4, half-maximal inhibitory concentration: 1320 nM
Estimate against measurement, compound 4: 9.1-fold (0.96 log units) above; the whole stated range lies above it.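

In this assay, within the data shown here, ethynyl in place of 1-benzofuran-2-yl, on the aromatic carbon two ring bonds from the ring nitrogen, gives an at least 15-fold lower number from compound 3 to compound 4 (1.18 log units; beyond the scatter), the first step at this position that lies beyond the scatter. Among these compounds, with ethynyl held in place, dimethylamino in place of methoxy gives a 9.6-fold lower number from compound 1 to compound 4 (0.98 log units; beyond the scatter), which shows that the number also depends on the second substituent on the shared core, something the earlier compounds could not show. The first of these steps fixes only a floor and not a true size, because compound 3 gives a limit and no number of its own: the limit of > 20000 nM in this assay, at which 2 of the 4 values shown sit.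

Going by these compounds, whether the number of compound 4 depends on ethynyl in particular remains open, and methyl, chloro or a longer alkyne chain on the same carbon would test that. Also open, on these data alone, are whether a primary amine or pyrrolidine in place of dimethylamino would move the number further, and whether the gain from dimethylamino holds with any group other than ethynyl on that carbon.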